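This account rests on a few compounds, and the source may have more. Where it says the series, first, only, none or still open, it means among the compounds named here.

Measured set:
compound 1, `CC1CCN(c2c(S(=O)(=O)c3ccc(Cl)cc3)cnc3cc(F)ccc23)CC1`: 90%
compound 2, `CC1CCN(c2c(S(=O)(=O)c3ccc(C#N)cc3)cnc3c(F)cccc23)CC1`: 86%
compound 3, `CC1CCN(c2c(S(=O)(=O)c3ccc(F)c(F)c3)cnc3ccc(F)cc23)CC1`: 82%

All three were run in an assay on isolated protein for displacement of a labelled ligand from metabotropic glutamate receptor 5 (Homo sapiens), with a stated time of 60 min, tested at 1 uM; a higher number here means more inhibition at the concentration tested (going by the name of the read-out), a lower number less inhibition. Compound 2 stands second highest of the three numbers; its nearest neighbour is compound 1, which lies higher by an amount within the scatter, and compound 3 lies lower, also within the scatter. On this read-out the three are not separable.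

Compound 4, `CC1CCN(c2c(S(=O)(=O)c3ccccc3)cnc3c(F)cccc23)CC1`, is still to be measured in this assay. Relative to compound 2 it shows (hydrogen in place of cyano on an aromatic carbon). For the measured compounds named here, no pair of measured compounds isolates a change of this kind, so any expectation rests on the three values alone. A modest loss is expected, the expected step being a number 11 percentage points lower from compound 2 to compound 4 (beyond the scatter), close to the edge of the scatter. The estimate for compound 4 is 75%, with a range from 55% to 90%.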

Compound 4, a percentage reported as inhibition, at one concentration (the size of the read-out at that concentration, not a potency): 13%
For compound 4 the middle estimate is 62 percentage points above the measured one; the whole stated range lies above it.
By their numbers in this assay, from the lowest: compound 4; then compounds 3, 2 and 1 (each within the scatter of the next).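

In this assay the 4-cyanophenyl to phenyl change gives a number 73 percentage points lower from compound 2 to compound 4 (beyond the scatter) and so shows that this place, para to a large group, is far from indifferent: with nothing else altered, most of the inhibition at the tested concentration is lost once cyano leaves. The earlier compounds shown here differ in more than one place and could not isolate this. No measurement available here bears on the reason for the loss. Open, as far as these compounds go, is whether an amine, a methoxy group or a carboxylic acid at this place would recover the inhibition. Also open, from the compounds shown here alone, is whether removing the group from compound 1 would cost as much.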